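The source may report more compounds than this note shows. Statements on the series, on what has been measured and on what is new or still open speak of the compounds shown alone.

Compound 1 `CCN(CC)C(=O)c1ccc(S(=O)(=O)N2CCC[C@@H](C(=O)N3CCN(c4nc(C(C)C)no4)CC3)C2)cc1`: 1400 nM in a functional assay on BXPC-3 cells (Homo sapiens) for inhibition, read by MTT assay, with a stated time of 7 days; on this read-out higher numbers stand for weaker inhibition and lower numbers for stronger inhibition
Compound 2 `CC(C)c1noc(N2CCN(C(=O)[C@@H]3CCCN(S(=O)(=O)c4ccc(S(=O)(=O)NC5CCC5)cc4)C3)CC2)n1`: 3300 nM in this assay

Compound 2 stands highest of the two numbers. Among the measured compounds shown here, the only measured step is a 2.4-fold higher number from compound 1 to compound 2 (0.37 log units; beyond the scatter), and it swaps the whole group on the aromatic carbon. Compound 3 `CCNS(=O)(=O)c1ccc(S(=O)(=O)N2CCC[C@@H](C(=O)N3CCN(c4nc(C(C)C)no4)CC3)C2)cc1` differs from compound 2 by ethyl in place of cyclobutyl on a sulfonamide nitrogen. For the measured compounds named here, no measured step touches the substituent on that sulfonamide nitrogen, so the earlier step gives little guidance, and no change beyond the scatter is expected. Compound 3 is therefore estimated at 2800 nM in this assay, within 1100 nM to 7000 nM. The expected step is a 1.2-fold lower number from compound 2 to compound 3 (0.07 log units; within the scatter).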

Compound 3, half-maximal inhibitory concentration: 6900 nM
Beside the measured number, compound 3's estimate is 2.5-fold (0.39 log units) below it; measured number inside the range.
By their numbers in this assay, from the lowest: compound 1; then compound 2; then compound 3.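

In this assay, among the compounds shown here, the group on the sulfonamide nitrogen matters: ethyl in place of cyclobutyl gives a 2.1-fold higher number from compound 2 to compound 3 (0.32 log units; beyond the scatter) and so moves the number beyond the scatter, which the earlier compounds could not show. Measured against the diethylcarbamoyl group of the first compound, ethylsulfamoyl gives a 4.9-fold higher number from compound 1 to compound 3 (0.69 log units; beyond the scatter) and stands as the largest step in the set. No evidence at hand accounts for either step.

Open, as far as these compounds go, is whether a cyclohexyl ring, a longer chain such as butyl, or a bare sulfamoyl group on that nitrogen would continue this trend or reverse it.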